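Halogen removal on the pendant aryl ring

This account rests on a few compounds, and the source may have more. Where it says the series, first, only, none or still open, it means among the compounds named here.

Compound 3 `Cc1cc(-c2ccccc2Cl)cc(C)c1Nc1ccnc(Nc2ccc(C#N)cc2)n1` carries a 2-chlorophenyl group on the shared core, and in an ADME assay on MT4 cells (Homo sapiens) for cytotoxicity, read by MTT assay, with a stated time of 4 days (a lower number here means that less compound is tolerated, a higher number that more compound is tolerated), compound 3 gives 3990 nM. Compound 1 `Cc1cc(-c2cccc(F)c2)cc(C)c1Nc1ccnc(Nc2ccc(C#N)cc2)n1` gives 4120 nM, and compound 2 `Cc1cc(-c2ccc(F)cc2)cc(C)c1Nc1ccnc(Nc2ccc(C#N)cc2)n1` gives 4170 nM. Compound 3 stands within the scatter of both neighbours, since a 1.0-fold lower number from compound 1 to compound 3 (0.01 log units; within the scatter) and a 1.0-fold lower number from compound 2 to compound 3 (0.02 log units; within the scatter), and the two fluorinated members are likewise close, as a 1.0-fold higher number from compound 1 to compound 2 (0.01 log units; within the scatter). Compound 4 `Cc1cc(-c2ccccc2)cc(C)c1Nc1ccnc(Nc2ccc(C#N)cc2)n1` is the next member: hydrogen in place of chloro on an aromatic carbon, so that 2-chlorophenyl becomes phenyl. Among the measured compounds shown here, the steps that bear on this change are the exchanges of one halogenated ring for another among compound 1, compound 2 and compound 3, none of which left the scatter. Removing the halogen altogether is a change of the same kind, and none of the three steps shows the halogen contributing anything measurable, so no step beyond the scatter is expected in this assay for compound 4. The estimate for compound 4 is therefore 4100 nM, with a range from 2500 nM to 6500 nM, which amounts to an expected step of a 1.0-fold higher number from compound 3 to compound 4 (0.01 log units; within the scatter).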

Compound 4, half-maximal cytotoxic concentration: 4170 nM
Compound 4: middle estimate off by 1.0-fold (0.01 log units), on the low side, and the stated range covers the measured number.
By their numbers in this assay, from the lowest: compounds 3, 1, 2 and 4 (each within the scatter of the next).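

Among the compounds shown here, compound 4 gives the series its first reading of halogen against hydrogen on the pendant ring, where the earlier steps only exchanged one halogenated ring for another. In this assay the chloro to hydrogen change gives a 1.0-fold higher number from compound 3 to compound 4 (0.02 log units; within the scatter) and stays within the scatter, and the two fluoro to hydrogen changes, no change at the digits printed from compound 2 to compound 4 (within the scatter) and a 1.0-fold higher number from compound 1 to compound 4 (0.01 log units; within the scatter), do the same, so none of the three halogenated rings differs measurably from plain phenyl. No measurement at hand bears on why these numbers coincide.

From the compounds shown here alone, whether this insensitivity extends to non-halogen groups on the pendant ring, such as an amine or a carboxylic acid, remains open. Also open, going by these compounds, is whether a longer chain in place of the phenyl would leave the number within the scatter.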